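Methyl added on the indole ring of compound 2

A few compounds are considered here, and "the series" means these few. Any claim that something is new, unique, unknown or untested is made for them only; others in the source may bear on it.

The series shares one core. Compound 1 `COc1ccc(Cl)c(-c2nnc3sc(-c4ccnc(F)c4)nn23)c1` carries a fluoropyridine on it, compound 2 `COc1ccc(Cl)c(-c2nnc3sc(Cc4c[nH]c5ccc(OC)cc45)nn23)c1` and compound 3 `COc1ccc2[nH]cc(Cc3nn4c(-c5ccoc5C)nnc4s3)c2c1` a methoxyindolylmethyl group. In a functional assay on the whole organism (strain Wistar Albino) for inhibition, with Rattus norvegicus as the target, read by paw edema, with a stated time of 1 h, at a dose of 20 mg/kg (a lower number here means less inhibition, a higher number more inhibition at the dose given (going by the name of the read-out)), compound 1 gives 18.5%. Compound 2 gives 6.1%, the lowest of the three numbers; compound 1 stands higher than compound 2 by a gap beyond the scatter. Compound 3 gives 16%, and the step of a number 9.9 percentage points higher from compound 2 to compound 3 (within the scatter) lies within the scatter.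

Compound 4 `COc1ccc(Cl)c(-c2nnc3sc(Cc4c(C)[nH]c5ccc(OC)cc45)nn23)c1` differs from compound 2 in one place: methyl in place of hydrogen on an aromatic carbon. Among the compounds with values here, the only measured step, a number 9.9 percentage points higher from compound 2 to compound 3 (within the scatter), changes the aryl group on the other side of the core and says nothing about a methyl on the indole ring, so no measured step bears on this change. With no guidance from the data, no step beyond the scatter is expected; the expected step is a number 1.9 percentage points higher from compound 2 to compound 4 (within the scatter). Compound 4 is therefore estimated at 8%, with a range from 0% to 22%.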

Compound 4, a percentage reported as inhibition, in the whole organism at one dose (the size of the read-out at that dose, not a potency): 11.3%
Estimate against measurement, compound 4: 3.3 percentage points below, and the stated range covers the measured number.
By their numbers in this assay, from the lowest: compounds 2, 4, 3 and 1 (each within the scatter of the next, the first and the last beyond it).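

In this assay, methyl in place of hydrogen on this aromatic carbon of the indole ring, next to the ring nitrogen, gives a number 5.2 percentage points higher from compound 2 to compound 4 (within the scatter). Within the data shown here, this is the first reading of a change on the indole ring itself, as the earlier step concerned the aryl group on the other side of the core. At this position, the added methyl produces no step beyond the scatter, so this single pair shows no clear gain or loss of inhibition. No measurement shown bears on what lies behind this result.

As far as these compounds go, whether an ethyl group, an amine or a carboxylic acid on this carbon would give a step beyond the scatter remains open. Also open, from the compounds shown here alone, is whether the same methyl would give a similar step with the 2-methylfuran-3-yl group of compound 3.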